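This account rests on a few compounds, and the source may have more. Where it says the series, first, only, none or still open, it means among the compounds named here.

Measured compounds:
- Compound 1, `COC(=O)c1c(F)cccc1OC(=O)COc1cc(O)c2c(=O)cc(-c3ccccc3)oc2c1`: in an ADME assay on cells (T-cell, Mus musculus, strain BALB/c) for cytotoxicity, read by MTT assay, with a stated time of 48 h (a lower number here means that less compound is tolerated, a higher number that more compound is tolerated), compound 1 gives 319000 nM.
- Compound 2, `COC(=O)c1cccc(Cl)c1OC(=O)COc1cc(O)c2c(=O)cc(-c3ccccc3)oc2c1`: in this assay compound 2 gives 366000 nM.

Among these two numbers compound 2 stands highest, and its only neighbour is compound 1, since a 1.1-fold higher number from compound 1 to compound 2 (0.06 log units; within the scatter). That step swaps one substituted ring for another, and the two values lie so close that they count as the same result.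

Compound 3, `COC(=O)c1c(Cl)cccc1OC(=O)COc1cc(O)c2c(=O)cc(-c3ccccc3)oc2c1`, has not yet been measured. It keeps every atom of compound 2, and the change is 3-chloro-2-(methoxycarbonyl)phenyl in place of 2-chloro-6-(methoxycarbonyl)phenyl on an oxygen next to a carbonyl group. Within the data shown here, only one measured step exists for comparison, the one from compound 1 to compound 2, and it was within the scatter. That step does not rehearse the same rearrangement, so the evidence is thin, but it gives no sign that shuffling the chlorine and the methoxycarbonyl group around this ring shifts the number much. The expected step is therefore a 1.1-fold lower number from compound 2 to compound 3 (0.03 log units; within the scatter), with no change beyond the scatter expected in either direction. Compound 3 is estimated at 340000 nM, with an expected range from 170000 nM to 680000 nM.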

Compound 3, half-maximal cytotoxic concentration: 366000 nM
The estimate for compound 3 lay 1.1-fold (0.03 log units) below the measured number; the measured number falls inside the stated range.
By their numbers in this assay, from the lowest: compounds 1, 2 and 3 (each within the scatter of the next).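

In this assay, 3-chloro-2-(methoxycarbonyl)phenyl in place of 2-chloro-6-(methoxycarbonyl)phenyl on an oxygen next to a carbonyl group gives no change at the digits printed from compound 2 to compound 3 (within the scatter), so joining the same atoms differently on this ring leaves the result the same within the scatter. Compound 3 also allows the halogen to be read on its own: chloro in place of fluoro on an aromatic carbon gives a 1.1-fold higher number from compound 1 to compound 3 (0.06 log units; within the scatter), whereas the earlier step from compound 1 to compound 2 changed the halogen and the arrangement of the ring together, and now neither change read separately goes beyond the scatter. Nothing measured here explains why these numbers agree.

All three compounds carry one halogen and a methoxycarbonyl group on this ring, so these results cover only a narrow range of substituents. Open, on these data alone, is whether a carboxylic acid or an amine in place of the methoxycarbonyl group, or a longer chain in place of its methyl, would give a number beyond the scatter of these three.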